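Trimethoxybenzoyl and trimethoxyphenyl-vinyl anilides on ovarian cells

The source may hold more compounds than are shown below. What is called first, only, known or untested is meant among the compounds shown, and "the series" means these compounds.

Measured so far:
compound 1, `CNCC(=O)Nc1cc(OC)ccc1C(=O)c1cc(OC)c(OC)c(OC)c1`: 580 nM
compound 2, `CCNCC(=O)Nc1cc(OC)ccc1C(=O)c1cc(OC)c(OC)c(OC)c1`: 950 nM
compound 3, `C=C(c1cc(OC)c(OC)c(OC)c1)c1ccc(OC)c(O)c1NC(=O)COC`: 450 nM

All three were run in a functional assay on A2780 cells (Homo sapiens) for antiproliferative activity, read by MTT assay, with a stated time of 48 h; on this read-out lower numbers stand for stronger inhibition and higher numbers for weaker inhibition. Compound 1 and compound 2 share a core and differ by methyl in place of hydrogen on a saturated chain carbon bound to an amine nitrogen; that step, a 1.6-fold higher number from compound 1 to compound 2 (0.21 log units; within the scatter), is within the scatter, so no order between them is claimed. Compound 3 sits on a different core; the difference between the two cores is not broken down here. Its value against compound 1 is within the scatter, while against compound 2 the gap is beyond it.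

Compound 4, `C=C(c1cc(OC)c(OC)c(OC)c1)c1ccc(OC)c(O)c1NC(=O)COCC`, has not yet been run in this assay. It differs from compound 3 by methyl in place of hydrogen on a saturated chain carbon bound to an oxygen on a saturated carbon. Going by the values given here, this is the same kind of change as the one from compound 1 to compound 2, though the place differs: there the carbon is bound to an amine nitrogen, here to an oxygen on a saturated carbon. Because a 1.6-fold higher number from compound 1 to compound 2 (0.21 log units; within the scatter) was small, a step of similar size is expected here, a 1.3-fold higher number from compound 3 to compound 4 (0.12 log units; within the scatter), with wider error since the core and surroundings differ. Compound 4 is therefore estimated at 600 nM, between 300 nM and 1300 nM.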

Compound 4, half-maximal inhibitory concentration: 1230 nM
For compound 4 the middle estimate is 2.1-fold (0.31 log units) below the measured one; measured number inside the range.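

In this assay, methyl in place of hydrogen on a saturated chain carbon bound to an oxygen on a saturated carbon gives a 2.7-fold higher number from compound 3 to compound 4 (0.44 log units; beyond the scatter), so on this core the methoxy to ethoxy change weakens inhibition beyond the scatter. Set beside the same kind of change on the core of compound 1, the two steps cannot be told apart: the same change on two cores in this assay, a 1.6-fold higher number (0.21 log units; within the scatter) from compound 1 to compound 2 and a 2.7-fold higher number (0.44 log units; beyond the scatter) from compound 3 to compound 4, 1.7-fold (0.22 log units) apart, within the scatter of two such steps They therefore give no sign that the change behaves differently on the two cores, but with one pair on each core, one step within the scatter and the carbon bound to a different atom in each pair, they do not establish that it carries over by a fixed amount.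

Still open, going by these compounds, is how a longer chain or a carboxylic acid in place of the entering methyl would read on either core. Also open, on these data alone, is whether the methoxy to ethoxy step would keep its size on the core of compound 1.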